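The compounds below may be only part of what the source reports. "The series", "measured", "known", "first", "only" and "open" are said of these compounds alone.

Of the compounds shown here, three sharing one core have been measured in a functional assay on SMMC-7721 cells (Homo sapiens) for cytotoxicity, read by MTT assay, with a stated time of 24 h; a higher number here means a weaker inhibitor, a lower number a stronger inhibitor. There, compound 1 `O=C1/C(=C/c2cccnc2)CN(S(=O)(=O)c2ccc(C(F)(F)F)cc2)C/C1=C\c1ccccc1F` gives 7900 nM, compound 2 `O=C1/C(=C/c2cccnc2)CN(S(=O)(=O)c2ccc(Cl)cc2)C/C1=C\c1ccccc1F` gives 16100 nM and compound 3 `CC(=O)Nc1ccc(S(=O)(=O)N2C/C(=C\c3cccnc3)C(=O)/C(=C/c3ccccc3F)C2)cc1` gives 10900 nM. Compound 2 thus has no clear separation from one neighbour, which shows a 1.5-fold lower number from compound 2 to compound 3 (0.17 log units; within the scatter), within the scatter, while the other shows a 2.0-fold higher number from compound 1 to compound 2 (0.31 log units; beyond the scatter), a modest step just beyond it.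

Compound 4 `O=C1/C(=C/c2cccnc2)CN(S(=O)(=O)c2ccc(Cl)cc2)C/C1=C\c1ccccc1C(F)(F)F` alters compound 2 in one place: trifluoromethyl in place of fluoro on an aromatic carbon. This puts trifluoromethyl in place of fluoro on an aromatic carbon, turning 2-fluorophenyl into 2-(trifluoromethyl)phenyl.

For the measured compounds named here, no measured step makes this swap or touches this ring. The nearest guide is how far changes on the other aromatic ring moved the number: a 2.0-fold higher number from compound 1 to compound 2 (0.31 log units; beyond the scatter) for chloro in place of trifluoromethyl, and a 1.4-fold higher number from compound 1 to compound 3 (0.14 log units; within the scatter) for acetamido in place of trifluoromethyl. Those steps are small, so no step beyond the scatter is expected, though this evidence is indirect. The expected change is a 1.2-fold lower number from compound 2 to compound 4 (0.09 log units; within the scatter). Compound 4 is estimated at 13000 nM, with an expected range from 6000 nM to 28000 nM.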

Compound 4, half-maximal inhibitory concentration: 4880 nM
The estimate for compound 4 lay 2.7-fold (0.43 log units) above the measured number; the whole stated range lies above it.
By their numbers in this assay, from the lowest: compounds 4, 1, 3 and 2 (each within the scatter of the next, the first and the last beyond it).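

The first change shown on the 2-fluorophenyl ring, which gives 2-(trifluoromethyl)phenyl, produces a 3.3-fold lower number from compound 2 to compound 4 (0.52 log units; beyond the scatter) in this assay. This position is therefore not silent: a single change here moves the number beyond the scatter, something the step from compound 1 to compound 3 on the other aromatic ring did not do. Although trifluoromethyl brings more heavy atoms than fluoro, and sits ortho to a large group, the number falls rather than rises, so a larger group at this place does not cost activity in this pair.

A single swap cannot show whether a methoxy group, an amine or a longer chain at this place would lower the number further or raise it again. Nothing measured here explains why the number fell.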